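Trading the thiocarbonyl amine: compound 1 to compound 4

A few compounds are considered here, and "the series" means these few. Any claim that something is new, unique, unknown or untested is made for them only; others in the source may bear on it.

Measured compounds:
compound 1 `CCN(Cc1ccncc1)C(=S)SCc1ccc(C(=O)Nc2ccccc2N)cc1`, 86.2%
compound 2 `Nc1ccccc1NC(=O)c1ccc(CSC(=S)N2CCN(Cc3ccccc3)CC2)cc1`, 29.3%
compound 3 `Nc1ccccc1NC(=O)c1ccc(CSC(=S)N2CCN(c3cnccn3)CC2)cc1`, 85.8%

In a functional assay on A-375 cells (Homo sapiens) for antiproliferative activity, read by CCK-8 assay, with a stated time of 72 h, tested at 8 uM (a lower number here means a weaker effect, a higher number a stronger effect of the compound at the concentration tested), compound 1 gives 86.2%, the highest of the three numbers; compound 3 sits within the scatter of it, while compound 2 lies far lower. Among the measured compounds shown here, the one step between measured compounds, a number 56.5 percentage points higher from compound 2 to compound 3 (beyond the scatter), concerns the amine nitrogen in the ring, not the thiocarbonyl carbon, so it bears on the new change only loosely: it shows that an aromatic ring set directly on an amine nitrogen is compatible with a high number, as in compound 3.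

Compound 4 `CN(C(=S)SCc1ccc(C(=O)Nc2ccccc2N)cc1)c1cccnc1` differs from compound 1 by methyl(pyridin-3-yl)amino in place of ethyl((pyridin-4-yl)methyl)amino on a thiocarbonyl carbon. For the measured compounds named here, no measured step touches this position, so the expectation rests on compound 1 itself and on the high reading of compound 3, which carries an aromatic ring on its amine nitrogen. The expected step is a number 10.2 percentage points lower from compound 1 to compound 4 (beyond the scatter), not beyond the scatter. Compound 4 is expected to give about 76%. For compound 4 the expected range runs from 50% to 92%.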

Compound 4, a percentage reported as inhibition, at one concentration (the size of the read-out at that concentration, not a potency): 87.7%
Compound 4: the middle estimate sits 11.7 percentage points below what was measured, and the stated range covers the measured number.
By their numbers in this assay, from the lowest: compound 2; then compounds 3, 1 and 4 (each within the scatter of the next).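

In this assay, methyl(pyridin-3-yl)amino in place of ethyl((pyridin-4-yl)methyl)amino on a thiocarbonyl carbon comes to a number 1.5 percentage points higher from compound 1 to compound 4 (within the scatter). Among the compounds shown here, this is the first measured step at this position, and it shows that the reading holds when the amine on this carbon is exchanged in this way, with the six-membered aromatic ring kept in both groups. No available evidence bears on why the reading holds.

The change alters the amine's alkyl group, the link to the ring and the ring's attachment point together, so the compounds shown do not separate these parts, and a read-out at a single concentration does not rank them by potency. On these data alone, whether a plain phenyl ring or a morpholine on the thiocarbonyl carbon would keep this reading remains open.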